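Acyl Exchange on the Ring Amide Nitrogen

The compounds below may be only part of what the source reports. "The series", "measured", "known", "first", "only" and "open" are said of these compounds alone.

Measured compounds:
compound 1, `CC1=C(C(=O)OC(C)C)C(c2cccc([N+](=O)[O-])c2)NC(=O)N1`, 46600 nM
compound 2, `COC(=O)N1C(=O)NC(C)=C(C(=O)OC(C)C)C1c1cccc([N+](=O)[O-])c1`, 2960 nM

In an assay on HEK293 cells for antagonist activity at Voltage-dependent L-type calcium channel subunit alpha-1D (Rattus norvegicus), read by FLIPR (a lower number here means a stronger inhibitor, a higher number a weaker inhibitor), compound 2 gives the lower of the two numbers, 2960 nM. Among the compounds with values here, the only measured step, a 16-fold lower number from compound 1 to compound 2 (1.20 log units; beyond the scatter), comes from methoxycarbonyl in place of hydrogen on an amide-type nitrogen in a ring. Compound 3, `CC1=C(C(=O)OC(C)C)C(c2cccc([N+](=O)[O-])c2)N(C(=O)C(C)C)C(=O)N1`, differs from compound 2 by isopropyl in place of methoxy on a carbonyl carbon. Within the data shown here, both keep an acyl group on that nitrogen, and no measured step tests the acyl group itself, so that large step does not carry over. For compound 3 the expected step is a 1.0-fold higher number from compound 2 to compound 3 (0.01 log units; within the scatter), within the scatter. Compound 3 is estimated at 3000 nM, between 1000 nM and 10000 nM.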

Compound 3, half-maximal inhibitory concentration: 990 nM
Compound 3: middle estimate off by 3.0-fold (0.48 log units), on the high side; the measured number lies below the stated range.
By their numbers in this assay, from the lowest: compound 3; then compound 2; then compound 1.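

In this assay the nature of the acyl group on the amide-type nitrogen in a ring proves to matter, not just its presence: isopropylcarbonyl in place of methoxycarbonyl gives a 3.0-fold lower number from compound 2 to compound 3 (0.48 log units; beyond the scatter) and this step lies beyond the scatter. Set against the hydrogen on that nitrogen, isopropylcarbonyl gives a 47-fold lower number from compound 1 to compound 3 (1.67 log units; beyond the scatter) and so the two acyl groups shown do not count alike. No evidence is available to explain the difference between them.

The compounds shown leave open how a longer chain, such as butyl, or an amine on a carbonyl carbon at this place would compare with isopropyl. They also leave open whether the difference between isopropylcarbonyl and methoxycarbonyl would persist with another group in place of the isopropyl ester.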